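Trimming the enone substituent in a shared ether series

The compounds below may be only part of what the source reports. "The series", "measured", "known", "first", "only" and "open" are said of these compounds alone.

Of the compounds shown here, three of a shared core have been measured in a functional assay on HL-60 cells (Homo sapiens) for inhibition, read by trypan blue exclusion, with a stated time of 72 h; a higher number here means a weaker inhibitor of growth, a lower number a stronger inhibitor of growth. Compound 1 `C=C(C)C(=O)c1ccc(OCc2nc(-c3ccccc3)cs2)c(C)c1C` gives 3400 nM. Compound 2 `C=C(CC)C(=O)c1ccc(OCc2nc(-c3ccc4ccccc4c3)cs2)c(C)c1C` gives 2000 nM, the second highest of the three numbers, and compound 3 `C=C(CC)C(=O)c1ccc(OCc2nc(-c3ccc(C(F)(F)F)cc3)cs2)c(C)c1C` gives 1500 nM. Compound 2 stands nearest to compound 3 and furthest from compound 1, and both gaps lie within the scatter. Going by the values given here, the only measured one-place step, a 1.3-fold lower number from compound 2 to compound 3 (0.12 log units; within the scatter), alters the aromatic substituent and also lies within the scatter.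

Compound 4 `C=C(C)C(=O)c1ccc(OCc2nc(-c3ccc4ccccc4c3)cs2)c(C)c1C` differs from compound 2 by hydrogen in place of methyl on a saturated chain carbon bound to a double-bonded chain carbon. Among the compounds with values here, no measured step touches this place, so the change has no direct precedent. Compound 1 also carries methyl rather than ethyl here, though with a different aromatic group, and its value and that of compound 2 lie within the scatter of each other. The step of a 1.3-fold higher number from compound 2 to compound 4 (0.10 log units; within the scatter) is therefore expected to stay within the scatter. Compound 4 is estimated at 2500 nM, with a range from 1200 nM to 5200 nM.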

Compound 4, concentration for 50% growth inhibition: 2300 nM
Estimate against measurement, compound 4: 1.1-fold (0.04 log units) above; the range from low to high includes it.
By their numbers in this assay, from the lowest: compounds 3, 2, 4 and 1 (each within the scatter of the next, the first and the last beyond it).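

In this assay, the place on a saturated chain carbon bound to a double-bonded chain carbon now has its first direct reading: ethyl to methyl, with the naphthalen-2-yl group held fixed, gives a 1.2-fold higher number from compound 2 to compound 4 (0.06 log units; within the scatter). Going by these compounds alone, compound 4 also gives the first one-place reading of the aromatic group with methyl at this chain position, where naphthalen-2-yl in place of phenyl gives a 1.5-fold lower number from compound 1 to compound 4 (0.17 log units; within the scatter). Neither change therefore separates the compounds it links, and no independent evidence explains either result.

The compounds shown leave open whether a longer chain such as butyl at this place would move the number beyond the scatter. They also leave open whether an amine or a carboxylic acid on the aromatic group would do so.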